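Amide substituent changes in the shared isoxazole-free core series

This account rests on a few compounds, and the source may have more. Where it says the series, first, only, none or still open, it means among the compounds named here.

Three compounds of the series have been run in a functional assay on CHO cells for antagonist activity at transient receptor potential cation channel subfamily V member 1 (Homo sapiens), read by fluorescence and calcium flux; on this read-out lower numbers stand for stronger inhibition and higher numbers for weaker inhibition. Compound 1 `O=C(N[C@H]1CCCC[C@H]1O)c1noc(-c2ccc(C(F)(F)F)cc2)c1Cl` gives 65 nM. Compound 2 `O=C(NC1CCCC1)c1noc(-c2ccc(Cl)cc2)c1Br` gives 370 nM; it differs from the others in several places. Compound 3 `O=C(N[C@H]1CC[C@H](O)CC1)c1noc(-c2ccc(C(F)(F)F)cc2)c1Cl` gives 392 nM and so stands at the high end of the three numbers; its separation from compound 2 lies within the scatter, while the step of a 6.0-fold higher number from compound 1 to compound 3 (0.78 log units; beyond the scatter) is beyond it.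

Compound 4 `COCCCNC(=O)c1noc(-c2ccc(C(F)(F)F)cc2)c1Cl` is not yet measured. The change from compound 3 is 3-methoxypropyl in place of 4-hydroxycyclohexyl on an amide-type nitrogen. For the measured compounds named here, only the single step from compound 1 to compound 3 touches this position, and it shows that moving the hydroxyl within the 4-hydroxycyclohexyl group already changes this assay by a modest amount; nothing in the set shows what removing the ring and the donor does. The step from compound 3 to compound 4 is therefore expected to be small, a 1.5-fold higher number from compound 3 to compound 4 (0.18 log units; within the scatter), with a slight lean toward a higher number. For compound 4 the estimate in this assay is 600 nM, with a range from 200 nM to 2000 nM.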

Compound 4, half-maximal inhibitory concentration: 2210 nM
For compound 4 the middle estimate is 3.7-fold (0.57 log units) below the measured one; the measured number lies above the stated range.
By their numbers in this assay, from the lowest: compound 1; then compounds 2 and 3 (each within the scatter of the next); then compound 4.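

In this assay, replacing the ring with an open chain at this amide-type nitrogen is not a neutral change: 3-methoxypropyl in place of 4-hydroxycyclohexyl gives a 5.6-fold higher number from compound 3 to compound 4 (0.75 log units; beyond the scatter), and 3-methoxypropyl in place of 2-hydroxycyclohexyl gives a 34-fold higher number from compound 1 to compound 4 (1.53 log units; beyond the scatter). With the rest of the core unchanged, both hydroxycyclohexyl groups therefore give lower numbers than the chain, which has no ring and no hydrogen-bond donor. No measurement at hand accounts for either step.

Ring and donor are lost together here, so it remains open which of them, if either alone, sets the size of these steps. A plain cyclohexyl group or a 3-hydroxypropyl chain on the same core would separate the two.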